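Phenyl in place of propyl on a carbonyl carbon

The source may report more compounds than this note shows. Statements on the series, on what has been measured and on what is new or still open speak of the compounds shown alone.

Compound 1, `CCCC(=O)N1c2ccccc2CCC1C(=O)Nc1cc(C(F)(F)F)cc(C(F)(F)F)c1`: 18600 nM
Compound 2, `CCC(=O)N1c2ccccc2CCC1C(=O)Nc1ccccc1C(F)(F)F`: > 80000 nM (a limit)
Compound 3, `O=C(Nc1ccc(O)cc1)C1CCc2ccccc2N1`: > 100000 nM (a limit)

In a functional assay on PC-3 cells (Homo sapiens) for cytotoxicity, read by sulforhodamine B assay, with a stated time of 72 h (on this read-out higher numbers stand for weaker inhibition of growth and lower numbers for stronger inhibition of growth), compound 1 gives 18600 nM, and this is the only number among the three results shown. Compound 2 yields no number but sits at the limit of > 80000 nM in this assay, at which 1 of the 3 values shown sits. Compound 3 likewise yields no number but sits at the limit of > 100000 nM in this assay, at which 1 of the 3 values shown sits. Going by the values given here, compound 1 therefore stands alone as the one compound of the set with a measured concentration for growth inhibition, while the two others show only that their inhibition is weaker than the assay could resolve.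

Compound 4, `O=C(Nc1cc(C(F)(F)F)cc(C(F)(F)F)c1)C1CCc2ccccc2N1C(=O)c1ccccc1`, keeps the core of compound 1 and its amide partner and differs in one place: phenyl in place of propyl on a carbonyl carbon. No pair of measured compounds shows this change, so its effect cannot be read from the data, and no reason for any shift can be given. Because compound 1 gives 18600 nM with nothing else to anchor a step, the expected step is one of modest size, if any, toward stronger inhibition, and it is expected to be a 1.7-fold lower number from compound 1 to compound 4 (0.23 log units; within the scatter), close to the usual scatter. Compound 4 is accordingly estimated at 11000 nM, with a range from 3500 nM to 40000 nM.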

Compound 4, concentration for 50% growth inhibition: 3500 nM
Compound 4: middle estimate off by 3.1-fold (0.50 log units), on the high side; the range from low to high includes it.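

In this assay, going by these compounds alone, the earlier compounds offered no pair differing in one place, and this is the first readable step at this position: phenyl in place of propyl on a carbonyl carbon gives a 5.3-fold lower number from compound 1 to compound 4 (0.73 log units; beyond the scatter). The step lies beyond the scatter and shows that, on the core of compound 1 with its amide partner unchanged, going from propylcarbonyl to benzoyl moves growth inhibition in the stronger direction, with a six-membered aromatic ring of carbon accepted at this place and no hydrogen-bond donor, hydrogen-bond acceptor or net charge entering with it. Nothing measured for either group bears on this step, and the compounds shown give no cause for it.

From the compounds shown here alone, it remains open whether the ring itself matters or only the larger group, a question that a cyclohexyl group or a longer chain such as hexyl on the same carbonyl carbon could address. Also open, going by these compounds, are whether the change carries over to the amide partner of compound 2, and how an amine or a carboxylic acid on the benzoyl ring would read in this assay.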